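The source may hold more compounds than are shown below. What is called first, only, known or untested is meant among the compounds shown, and "the series" means these compounds.

Measured so far:
Compound 1 `C=C[C@@](C)(/C=C/c1ccc(O)cc1)CC/C=C/C(=O)OCC` gives > 49000 nM in a functional assay on Jurkat cells (Homo sapiens) for cytotoxicity, with a stated time of 72 h (on this read-out higher numbers stand for an effect only at larger amounts of compound and lower numbers for an effect already at smaller amounts), which is a limit of the assay rather than a number.
Compound 2 `C=C[C@@](C)(/C=C/c1ccc(O)cc1)CC/C=C/C#N` gives > 49000 nM in this assay, likewise a limit.
Compound 3 `C=C[C@@](C)(/C=C/c1ccc(O)c(/C=C/C#N)c1)CCC=C(C)C` gives > 49000 nM in this assay, again a limit.

Compound 4 `C=C[C@@](C)(/C=C/c1ccc(O)c(/C=C/C(=O)OCC)c1)CCC=C(C)C` has not yet been measured in this assay. It differs from compound 3 by ethoxycarbonyl in place of cyano on a double-bonded chain carbon bound to a double-bonded chain carbon. The same change, (ethoxycarbonyl in place of cyano on a double-bonded chain carbon bound to a double-bonded chain carbon), also runs from compound 2 to compound 1, where the two measurements give a step that the two limits leave unreadable from compound 2 to compound 1. How the core of compound 2 differs from the core of compound 3 is not broken down here. For the measured compounds named here, every value so far sits at the limit of > 49000 nM in this assay, at which 3 of the 3 values shown sit, so the measured pair cannot show how large this change is.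

Compound 4 is expected in this assay at about 70000 nM, with an estimated range from 25000 nM to 250000 nM. That expectation rests on compound 3 and on compound 1 and compound 2 all sitting at the limit of > 49000 nM in this assay, at which 3 of the 3 values shown sit. The estimate means an expected step that the limit leaves unreadable from compound 3 to compound 4, with a strong chance that the assay again reports only a limit.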

Compound 4, half-maximal effective concentration: > 49000 nM
Compound 4: only a limit was reported (the forecaster's own chance of this, stated with the estimate: 85%); the middle value does not contradict the limit.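

No step can be read between compound 3 and compound 4, nor between compound 2 and compound 1, since both members of each pair give only a limit in this assay: the limit of > 49000 nM in this assay, at which 4 of the 4 values shown sit.
The compounds shown leave open how large the change to ethoxycarbonyl from cyano is and how these four compounds rank in this assay.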